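A few compounds are considered here, and "the series" means these few. Any claim that something is new, unique, unknown or untested is made for them only; others in the source may bear on it.

Of the compounds shown here, three built on one shared core have been measured in a functional assay on HCT-116 cells (Homo sapiens) for inhibition, read by MTT assay, with a stated time of 48 h; on this read-out higher numbers stand for weaker inhibition and lower numbers for stronger inhibition. Compound 1 `Fc1ccc(CSc2nnc(-c3ccncc3)n2-c2ccccc2)cc1` gives 12800 nM in this assay. Compound 2 `O=[N+]([O-])c1ccc(CSc2nnc(-c3ccncc3)n2-c2ccccc2)cc1`, which carries a nitro group in place of the fluoro group on an aromatic carbon, gives 23800 nM. That single swap amounts to a 1.9-fold higher number from compound 1 to compound 2 (0.27 log units; within the scatter). Compound 3 `O=C(CSc1nnc(-c2ccncc2)n1-c1ccccc1)N/N=C/c1ccc(F)cc1`, which carries a 4-fluorophenyl group on a carbon with a double bond to nitrogen, gives 7040 nM; its number is the lowest of the three, yet it sits within the scatter of compound 1, so those two cannot be told apart, while its number is clearly lower than that of compound 2.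

Compound 4 `O=C(CSc1nnc(-c2ccncc2)n1-c1ccccc1)N/N=C/C=C/c1ccccc1` has not yet been measured. It differs from compound 3 in one place: 2-phenylethenyl in place of 4-fluorophenyl on a carbon with a double bond to nitrogen. Going by the values given here, none of the measured steps touches this position; the only measured step, from compound 1 to compound 2, changes a substituent on a different part of the molecule and is within the scatter. With nothing bearing on the change, no shift beyond the scatter is expected, so the expected step from compound 3 to compound 4 is a 1.1-fold lower number from compound 3 to compound 4 (0.03 log units; within the scatter). Compound 4 is therefore estimated at 6500 nM in this assay, with a range from 2500 nM to 17000 nM.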

Compound 4, half-maximal inhibitory concentration: 6150 nM
Compound 4: the middle estimate sits 1.1-fold (0.02 log units) above what was measured; the measured number falls inside the stated range.
By their numbers in this assay, from the lowest: compounds 4, 3, 1 and 2 (each within the scatter of the next, the first and the last beyond it).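

In this assay, the first step measured on a carbon with a double bond to nitrogen is a 1.1-fold lower number from compound 3 to compound 4 (0.06 log units; within the scatter) and so leaves compound 3 and compound 4 indistinguishable. Going by these compounds alone, the earlier step changed a different part of the molecule, so this is the first sign that the group at this place can be exchanged without a difference beyond the scatter, at least for this pair: 4-fluorophenyl gives way to 2-phenylethenyl, the fluorine is lost, a double bond outside aromatic rings is added, and the six-membered aromatic ring of carbon is kept. No supporting data are available to explain this result.

On these data alone, both groups compared here carry that same carbon-only aromatic ring, so it remains open whether the ring itself matters at this place. A plain alkyl chain, or a phenyl ring bearing an amine or a carboxylic acid, could show whether this place accepts groups of a different kind or whether the numbers would then move beyond the scatter.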